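This account rests on a few compounds, and the source may have more. Where it says the series, first, only, none or still open, it means among the compounds named here.

In a toxicity assay on THP-1 cells (Homo sapiens) for inhibition (a lower number here means that less compound is tolerated, a higher number that more compound is tolerated), compound 3 (`COc1ccc(-c2cnc(NC(=O)c3ccc(C)cc3)n2C)cc1`) gives > 100000 nM, which is a limit of the assay and not a number. Compound 1 (`COc1ccc(-c2cnc(NC(=O)c3ccc(Br)cc3)n2C)cc1`) gives > 100000 nM, also a limit. Compound 2 (`COc1ccc(-c2cnc(NC(=O)c3cnco3)n2C)cc1`) gives > 100000 nM, again a limit. Among the measured compounds shown here, the series so far therefore stands at the limit of > 100000 nM in this assay, at which 3 of the 3 values shown sit.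

Compound 4 (`COc1ccc(-c2cnc(NC(=O)c3ccc(F)cc3)n2C)cc1`) differs from compound 3 by fluoro in place of methyl on an aromatic carbon, para to a large group. The nearest measured change is a step that the two limits leave unreadable from compound 1 to compound 3. The other two, a step that the two limits leave unreadable from compound 1 to compound 2 and a step that the two limits leave unreadable from compound 2 to compound 3, are no more informative. No measured size supports a shift, so a number no higher from compound 3 to compound 4 (the limit leaves the size open) is expected to stay within the scatter in this assay, with no direction. Compound 4 is estimated at 100000 nM, with an expected range from 50000 nM to 200000 nM.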

Compound 4, half-maximal cytotoxic concentration: >= 50000 nM
Compound 4 was reported as a limit (the forecaster's own chance of this, stated with the estimate: 90%); the middle value does not contradict the limit.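

Compound 4 gives >= 50000 nM in this assay, a limit and not a number. Its steps to compound 1, compound 2 and compound 3 cannot be read. The compounds shown leave open what half-maximal cytotoxic concentration any of them actually has.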